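From imidazole to methylpiperazine on the propyl chain

The compounds below may be only part of what the source reports. "The series", "measured", "known", "first", "only" and "open" are said of these compounds alone.

Among the measured compounds shown here, in a functional assay on K562 cells (Homo sapiens) for antiproliferative activity, read by MTT assay, with a stated time of 48 h (a lower number here means a stronger inhibitor, a higher number a weaker inhibitor), compound 2 `Cn1cc(C2=C(c3nn(CCCn4ccnc4)c4ncccc34)C(=O)NC2=O)c2ccccc21` gives 13800 nM as the only true number so far. For compound 1 `Cn1cc(C2=C(c3nn(CCCn4cncn4)c4ncccc34)C(=O)NC2=O)c2ccccc21` the reading > 100000 nM is a limit and not a number.

Compound 3 `CN1CCN(CCCn2nc(C3=C(c4cn(C)c5ccccc45)C(=O)NC3=O)c3cccnc32)CC1` keeps the shared core and the propyl chain and alters one group: 4-methylpiperazin-1-yl in place of 1H-imidazol-1-yl on a saturated chain carbon, three bonds along the chain from an aromatic nitrogen. The 4-methylpiperazin-1-yl group sits on a saturated chain carbon, three bonds along the chain from an aromatic nitrogen, where 1H-imidazol-1-yl stood in compound 2.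

For the measured compounds named here, one measured step bears on this place, an at least 7.2-fold lower number from compound 1 to compound 2 (0.86 log units; beyond the scatter), and it shows that this assay responds to a swap of the group on this chain. That step joins two aromatic rings, so it offers no direct guide to a non-aromatic ring and sets only a loose expectation. A modest move to a lower number is expected, and the estimated change is a 2.3-fold lower number from compound 2 to compound 3 (0.36 log units; beyond the scatter) with considerable uncertainty. For compound 3 the estimated value is 6000 nM within an expected range from 1500 nM to 25000 nM.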

Compound 3, half-maximal inhibitory concentration: 46700 nM
Compound 3: middle estimate off by 7.8-fold (0.89 log units), on the low side; the measured number lies above the stated range.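

Replacing 1H-imidazol-1-yl with 4-methylpiperazin-1-yl on the propyl chain gives a 3.4-fold higher number from compound 2 to compound 3 (0.53 log units; beyond the scatter) in this assay, so a change of group at this position does not always move the number downward. Measured against 1H-1,2,4-triazol-1-yl, the same 4-methylpiperazin-1-yl group gives an at least 2.1-fold lower number from compound 1 to compound 3 (0.33 log units; beyond the scatter), which places compound 3 between compound 2 and compound 1 in this three-member series. Compound 1 is held only by a limit, so that last step gives a minimum size and not a measured one: the limit of > 100000 nM in this assay, at which 1 of the 3 values shown sits.

With a single non-aromatic ring in the series, the compounds shown cannot separate the loss of the aromatic ring from the larger group or from its added methyl group. Going by these compounds, it remains open whether an unsubstituted piperazine, a morpholine or a dimethylamino group on the same propyl chain would fall nearer compound 2 or compound 3 in this assay, and whether a shorter or longer chain carrying 1H-imidazol-1-yl would change the number.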